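This account rests on a few compounds, and the source may have more. Where it says the series, first, only, none or still open, it means among the compounds named here.

Compound 1 `COc1cccc(C(=O)N(C)c2ccc3[nH]c(-c4n[nH]c5ccccc45)cc3n2)c1` and compound 2 `CN(c1ccc2[nH]c(-c3n[nH]c4ccccc34)cc2n1)S(=O)(=O)c1ccc(OC(F)(F)F)cc1` share a common core and differ only in the group carried on the methylated nitrogen. In a functional assay on KB cells (Homo sapiens) for antiproliferative activity, read by MTT assay, with a stated time of 72 h (on this read-out lower numbers stand for stronger inhibition and higher numbers for weaker inhibition), compound 1 gives 9010 nM, the higher of the two numbers, while compound 2 gives 1330 nM; that gap lies beyond the usual scatter, so compound 1 is the weaker of the pair. Compound 3 `CN(C(=O)Nc1ccccc1)c1ccc2[nH]c(-c3n[nH]c4ccccc34)cc2n1` has not yet been measured. It arises from compound 1 by a single change: anilino in place of 3-methoxyphenyl on a carbonyl carbon. Cut one bond further out, the difference reads as (3-methoxyphenyl)carbonyl giving way to phenylcarbamoyl. Going by the values given here, no measured pair shows this exact change, so its effect cannot be read off from the two compounds in hand. A step of moderate size toward a lower number is expected, since compound 2, which carries a different group at the same nitrogen, gives 1330 nM and shows that numbers here can fall well under that of compound 1. The expected step is a 1.8-fold lower number from compound 1 to compound 3 (0.26 log units; within the scatter). Compound 3 is estimated at 5000 nM, with a range from 1500 nM to 16000 nM.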

Compound 3, half-maximal inhibitory concentration: 32 nM
Beside the measured number, compound 3's estimate is 160-fold (2.19 log units) above it; measured number outside the range, below it.
By their numbers in this assay, from the lowest: compound 3; then compound 2; then compound 1.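

In this assay, anilino in place of 3-methoxyphenyl on a carbonyl carbon gives a 280-fold lower number from compound 1 to compound 3 (2.45 log units; beyond the scatter), showing that the group at this place can change the number very strongly. The size of the step stands out given how much the two groups have in common: each brings one six-membered aromatic ring of carbon only, while anilino adds a nitrogen with 1 hydrogen-bond donor and the methoxy oxygen, with its 1 hydrogen-bond acceptor, is gone. Nothing available accounts for the size of this step.

Because the nitrogen arrives as the methoxy group leaves, the compounds shown cannot tell how much of the step belongs to each change, and a 3-methoxyanilino group on the same carbonyl carbon would help to separate the two. They also leave open whether the aromatic ring is needed at all, a question that a simple amine such as methylamino or cyclohexylamino in place of anilino would address.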